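The source may hold more compounds than are shown below. What is called first, only, known or untested is meant among the compounds shown, and "the series" means these compounds.

Measured compounds:
- compound 1, `c1ccc(-c2cn3ccnc3c(-c3ccc4ncn(C5CCCCC5)c4c3)n2)cc1`, 67.7%
- compound 2, `COc1ccc(-c2cn3ccnc3c(-c3ccc4ncn(C5CCCCC5)c4c3)n2)cc1`, 82.8%
- compound 3, `c1cn2cc(-c3ccsc3)nc(-c3ccc4ncn(C5CCCCC5)c4c3)c2n1`, 30%

Of the compounds shown here, three sharing one core have been tested in a functional assay on MOLT-4 cells (Homo sapiens) for inhibition, read by sulforhodamine B assay, with a stated time of 48 h, tested at 10 uM; a lower number here means less inhibition, a higher number more inhibition at the concentration tested (going by the name of the read-out). Compound 1 gives 67.7%, compound 2 gives 82.8%, and compound 3 gives 30%. Compound 3 stands lowest of the three; its nearest neighbour is compound 1, a step of a number 37.7 percentage points lower from compound 1 to compound 3 (beyond the scatter), and its furthest is compound 2, a step of a number 52.8 percentage points lower from compound 2 to compound 3 (beyond the scatter).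

The next compound, compound 4, `COc1ccccc1-c1cn2ccnc2c(-c2ccc3ncn(C4CCCCC4)c3c2)n1`, has not yet been measured. It differs from compound 3 in one place: 2-methoxyphenyl in place of thiophen-3-yl on an aromatic carbon.

For the measured compounds named here, two measured steps bear on this change. The step of a number 37.7 percentage points lower from compound 1 to compound 3 (beyond the scatter) shows what the move from phenyl to thiophen-3-yl did, and its reverse suggests that a carbon-only six-membered ring in that place would be expected to give a large rise. The step of a number 15.1 percentage points higher from compound 1 to compound 2 (beyond the scatter) shows that a methoxy group on that ring gave a modest further rise, although there it sat in a different position on the ring, so its contribution for compound 4 is uncertain. Taken together, compound 4 is expected to show a large rise, a number 38 percentage points higher from compound 3 to compound 4 (beyond the scatter), landing near compound 1. The estimate for compound 4 is 68%, with a range from 45% to 88%.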

Compound 4, a percentage reported as inhibition, at one concentration (the size of the read-out at that concentration, not a potency): 22.4%
Compound 4: middle estimate off by 45.6 percentage points, on the high side, and the stated range ends above it.
By their numbers in this assay, from the lowest: compounds 4 and 3 (each within the scatter of the next); then compound 1; then compound 2.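

In this assay, the step of a number 7.6 percentage points lower from compound 3 to compound 4 (within the scatter) shows that a carbon-only six-membered ring at this place does not by itself bring the inhibition back, since 2-methoxyphenyl and thiophen-3-yl cannot be told apart here. The earlier compounds shown here showed methoxy on the phenyl ring only as 4-methoxyphenyl, with a step of a number 15.1 percentage points higher from compound 1 to compound 2 (beyond the scatter); the new compound reverses that direction, with a step of a number 45.3 percentage points lower from compound 1 to compound 4 (beyond the scatter), and moving from 4-methoxyphenyl to 2-methoxyphenyl gives a step of a number 60.4 percentage points lower from compound 2 to compound 4 (beyond the scatter), so at this place the outcome for methoxy depends on where it sits on the ring. No measurement among the data shown accounts for this difference.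

The compounds shown leave open whether the oxygen of the methoxy group matters or any substituent at that ring position would do the same, a question that a methyl group or a fluorine in the same ring position as in compound 4 could address. They also leave open how an amine or a carboxylic acid, or a longer ether chain in place of methoxy, would read in this assay on this ring.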